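The source may hold more compounds than are shown below. What is called first, only, known or untested is meant among the compounds shown, and "the series" means these compounds.

Measured so far:
compound 1, `Cc1nn(-c2ccc3ncccc3c2)c2nc(Nc3cnn(C4CCNCC4)c3)ncc12`, 11 nM
compound 2, `Brc1nn(-c2ccc3ncccc3c2)c2nc(Nc3cnn(C4CCNCC4)c3)ncc12`, 3 nM

In an assay on isolated protein for inhibition of eIF-2-alpha kinase GCN2 (Homo sapiens) (on this read-out lower numbers stand for stronger inhibition and higher numbers for weaker inhibition), compound 2 holds the lowest of the two numbers; the nearest number is that of compound 1, and that step, a 3.7-fold lower number from compound 1 to compound 2 (0.56 log units; beyond the scatter), lies beyond the scatter. Compound 3 is `FC(F)(F)c1nn(-c2ccc3ncccc3c2)c2nc(Nc3cnn(C4CCNCC4)c3)ncc12`. Relative to compound 2 the change is trifluoromethyl in place of bromo on an aromatic carbon. Among the measured compounds shown here, the only measured step at this carbon is the exchange of methyl for bromo, a 3.7-fold lower number from compound 1 to compound 2 (0.56 log units; beyond the scatter), a modest lowering; no step from bromo to any further group has been measured, so the present change rests on that single comparison. Both groups tried at this carbon have given low numbers, and a further step of similar size in either direction would be no surprise, but none beyond the scatter is assumed. Compound 3 is therefore expected to give about 4 nM (range 1.5 nM to 12 nM), which corresponds to an expected step of a 1.3-fold higher number from compound 2 to compound 3 (0.12 log units; within the scatter).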

Compound 3, half-maximal inhibitory concentration: 168 nM
Beside the measured number, compound 3's estimate is 42-fold (1.62 log units) below it; measured number above the stated range.
By their numbers in this assay, from the lowest: compound 2; then compound 1; then compound 3.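

In this assay this aromatic carbon proves far less permissive than methyl and bromo alone suggested: exchanging bromo for trifluoromethyl gives a 56-fold higher number from compound 2 to compound 3 (1.75 log units; beyond the scatter) and exchanging methyl for trifluoromethyl gives a 15-fold higher number from compound 1 to compound 3 (1.18 log units; beyond the scatter). Both steps exceed a 3.7-fold lower number from compound 1 to compound 2 (0.56 log units; beyond the scatter) in size, so the outcome at this carbon depends strongly on the group it carries, and trifluoromethyl stands apart from the other two groups. Nothing available bears on what lies behind this rise.

Going by these compounds, whether chloro, ethyl, cyclopropyl or a nitrile at this carbon would fall with methyl and bromo or with trifluoromethyl remains open. Also open, on these data alone, is whether the same exchange would have a similar effect with a group other than quinolin-6-yl on the shared core.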